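This account rests on a few compounds, and the source may have more. Where it says the series, first, only, none or still open, it means among the compounds named here.

In a functional assay on A549 cells (Homo sapiens) for antiproliferative activity, read by MTT assay, with a stated time of 72 h (on this read-out lower numbers stand for stronger inhibition and higher numbers for weaker inhibition), three compounds with a shared core have been measured. Compound 1 `C#Cc1cccc(Nc2ncnc3cc(OC)c(OCCCN4CCNCCNCCNCC4)cc23)c1` gives 28600 nM, compound 2 `COc1cc2ncnc(Nc3cccc(Br)c3)c2cc1OCCCN1CCNCCNCCNCC1` gives 14700 nM and compound 3 `COc1cc2ncnc(Nc3cccc(Br)c3)c2cc1OCCCN1CCNCCNCC1` gives 34300 nM. Compound 3 therefore lies within the scatter of compound 1, while its number is beyond the scatter from the lower one of compound 2.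

The next compound, compound 4 `COc1cc2ncnc(Nc3cccc(I)c3)c2cc1OCCCN1CCNCCNCC1`, differs from compound 3 by one atom: iodo in place of bromo on an aromatic carbon. This is iodo in place of bromo on an aromatic carbon, meta to a large group. Among the measured compounds shown here, no measured compound yet carries iodo, so the evidence is indirect. For the measured compounds named here, the nearest precedent is another exchange on an aromatic carbon, a 1.9-fold lower number from compound 1 to compound 2 (0.29 log units; within the scatter), which stayed within the scatter. The other measured step, a 2.3-fold higher number from compound 2 to compound 3 (0.37 log units; beyond the scatter), was modest, but it concerns the large ring on the saturated chain, which stays the same here.

No change beyond the scatter is therefore expected in this assay, and the estimated step is a 1.2-fold lower number from compound 3 to compound 4 (0.07 log units; within the scatter). Compound 4 is expected at 29000 nM, with an estimated range of 14000 nM to 58000 nM.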

Compound 4, half-maximal inhibitory concentration: 26200 nM
Compound 4: middle estimate off by 1.1-fold (0.04 log units), on the high side; measured number inside the range.
By their numbers in this assay, from the lowest: compounds 2, 4, 1 and 3 (each within the scatter of the next, the first and the last beyond it).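

In this assay, 3-iodophenyl in place of 3-bromophenyl gives a 1.3-fold lower number from compound 3 to compound 4 (0.12 log units; within the scatter). This is the second exchange at this place on the six-membered aromatic ring of carbon only, and like a 1.9-fold lower number from compound 1 to compound 2 (0.29 log units; within the scatter), which was made on the larger non-aromatic ring, it stays within the scatter, now with the nine-membered ring in place, so among these compounds neither exchange on the aromatic carbon moves the number beyond the scatter. No measurement at hand bears on why the iodo and bromo compounds read alike.

The compounds shown leave open whether chloro or fluoro at this place would also stay within the scatter. Going by these compounds, it is also open whether iodo would behave the same way with the larger non-aromatic ring, or with a longer chain leading to the ring.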